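A few compounds are considered here, and "the series" means these few. Any claim that something is new, unique, unknown or untested is made for them only; others in the source may bear on it.

Measured compounds in this series:

compound 1 `CC(C)C[C@@H](N)CN(C(=O)[C@@H]1C[C@H]1c1ccccc1)c1ccc(-c2ccccc2)cc1` — 1.8 nM
compound 2 `CC[C@@H](C)[C@H](N)CN(C(=O)[C@@H]1C[C@H]1c1ccccc1)c1ccc(-c2ccccc2)cc1` — 1.4 nM
compound 3 `CCc1ccc(-c2ccc(N(C[C@@H](N)[C@@H](C)CC)C(=O)[C@@H]3C[C@H]3c3ccccc3)cc2)cc1` — 44 nM

For the measured compounds named here, in a functional assay for agonist activity at G protein-coupled receptor 88 (Homo sapiens), read by HTRF and cAMP accumulation (on this read-out higher numbers stand for an effect only at larger amounts of compound and lower numbers for an effect already at smaller amounts), compound 3 stands highest of the three numbers; the only step between measured compounds that differ in one place is a 1.3-fold lower number from compound 1 to compound 2 (0.11 log units; within the scatter), and it concerns the amine-bearing chain, not the distal aromatic ring. Going by the values given here, compound 3 has no single-point step to either of the others; its value is simply far above those of compound 1 and compound 2.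

Compound 4 `CC[C@H](C)[C@H](N)CN(C(=O)[C@@H]1C[C@H]1c1ccccc1)c1ccc(-c2ccc(Oc3ccccc3)cc2)cc1` differs from compound 3 by phenoxy in place of ethyl on an aromatic carbon. Among the compounds with values here, no measured step bears on this change: the one available step touches a different part of the molecule and is within the scatter, so it gives no guide to what a larger group on the distal ring will do. The only relevant observation is that compound 3, which already carries ethyl at this position, sits well above the unsubstituted compound 1 in this assay.

Compound 4 is therefore expected to remain in the same region as compound 3, with the step of a 1.4-fold higher number from compound 3 to compound 4 (0.13 log units; within the scatter) estimated as small and uncertain in direction. The estimate for compound 4 in this assay is 60 nM, within 15 nM to 250 nM.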

Compound 4, half-maximal effective concentration: 94 nM
Beside the measured number, compound 4's estimate is 1.6-fold (0.19 log units) below it, and the stated range covers the measured number.
By their numbers in this assay, from the lowest: compounds 2 and 1 (each within the scatter of the next); then compound 3; then compound 4.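

In this assay, for the compounds shown here, replacing ethyl with phenoxy on this aromatic carbon, para to a large group, gives a 2.1-fold higher number from compound 3 to compound 4 (0.33 log units; beyond the scatter), the first reading of a single change at this position. The step is modest although the incoming group has 7 heavy atoms against 2 for ethyl, and it adds a six-membered aromatic ring and a hydrogen-bond acceptor, so this position tolerates a much larger group at a limited cost in this series. No available data explain the direction or the size of this step.

The compounds shown do not separate the contribution of the ether oxygen from that of the added ring, and a phenyl or benzyl group at this carbon would help to tell the two apart, while a methoxy group, a carboxylic acid or an amine would test other kinds of substituent there. As far as these compounds go, it also remains open whether the step from ethyl to phenoxy would be the same size on the 1-amino-3-methylbutyl chain of compound 1, since both compounds in this step carry the 1-amino-2-methylbutyl chain.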